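The source may hold more compounds than are shown below. What is called first, only, known or untested is meant among the compounds shown, and "the series" means these compounds.

Three compounds share one core and differ only in the ring attached to the sulfonyl sulfur. Compound 1 `CC1CCN(C2CCN(S(=O)(=O)c3ccccc3Br)CC2)CC1` gives 3 nM in a functional assay on DLD-1 cells (Homo sapiens) for antiproliferative activity, read by CellTiter-Glo, with a stated time of 72 h; on this read-out higher numbers stand for weaker inhibition and lower numbers for stronger inhibition. Compound 2 `CC1CCN(C2CCN(S(=O)(=O)c3ccccc3-c3ccccc3)CC2)CC1`, which carries the change (phenyl in place of bromo on an aromatic carbon), gives 0.96 nM, a step of a 3.1-fold lower number from compound 1 to compound 2 (0.49 log units; beyond the scatter). Compound 3 `CC1CCN(C2CCN(S(=O)(=O)c3cccc(Br)c3)CC2)CC1` gives 3.2 nM, a step of a 1.1-fold higher number from compound 1 to compound 3 (0.03 log units; within the scatter); the two cores of compound 1 and compound 3 differ by 3-bromophenyl in place of 2-bromophenyl on a sulfonyl sulfur.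

Compound 4 `CC1CCN(C2CCN(S(=O)(=O)c3cccc(-c4ccccc4)c3)CC2)CC1` is not yet measured. It carries the change (phenyl in place of bromo on an aromatic carbon), the same kind of change that turned compound 1 into compound 2, though there the phenyl entered ortho to a large group and here it enters meta to a large group, so the two changes are alike in kind but not the same. Since the two bromo compounds sit within the scatter of each other, the step from compound 3 to compound 4 is expected to resemble the earlier one, about a 2.9-fold lower number from compound 3 to compound 4 (0.46 log units; beyond the scatter), resting on a 3.1-fold lower number from compound 1 to compound 2 (0.49 log units; beyond the scatter). Compound 4 is therefore expected to give about 1.1 nM in this assay, likely between 0.4 nM and 3 nM.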

Compound 4, half-maximal inhibitory concentration: 2 nM
The estimate for compound 4 lay 1.8-fold (0.26 log units) below the measured number; measured number inside the range.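

The newly measured step is a 1.6-fold lower number from compound 3 to compound 4 (0.20 log units; within the scatter) and so, taken alone, it cannot be told apart from the ordinary variation between repeated measurements. Among the compounds shown here, the change from bromo to phenyl therefore has a clear effect on only one of the two cores, yet the two steps cannot be separated from each other either. Set side by side, they show no measurable dependence on the core, though this does not prove the steps are equal, and two pairs of compounds say nothing about any further core in the series: the same change on two cores in this assay, a 3.1-fold lower number (0.49 log units; beyond the scatter) from compound 1 to compound 2 and a 1.6-fold lower number (0.20 log units; within the scatter) from compound 3 to compound 4, 2.0-fold (0.29 log units) apart, within the scatter of two such steps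

The compounds shown carry only bromo or phenyl on the ring attached to the sulfonyl sulfur, so it remains open what an amine, a carboxylic acid or a nitrile would do in that place. Also open, as far as these compounds go, is how the change from bromo to phenyl behaves outside this assay.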